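Replacing Methyl with Fluoro in an Antiproliferative Series

The source may hold more compounds than are shown below. What is called first, only, known or untested is meant among the compounds shown, and "the series" means these compounds.

Going by the values given here, in a functional assay on SGC-7901 cells (Homo sapiens) for antiproliferative activity, read by MTT assay, with a stated time of 48 h (on this read-out lower numbers stand for stronger inhibition and higher numbers for weaker inhibition), compound 1 `Cc1ccccc1-c1nnc(SCc2ccc(Cl)nc2)o1` gives 8.51 ug/mL and so holds the higher of the two numbers measured so far. In this assay compound 2 `COc1ccc(-c2nnc(SCc3ccc(Cl)nc3)o2)cc1` gives 3.5 ug/mL as its reading, and this gap between the two compounds lies beyond the usual scatter.

Compound 3 `Fc1ccccc1-c1nnc(SCc2ccc(Cl)nc2)o1` differs from compound 1 in one place: fluoro in place of methyl on an aromatic carbon turns 2-methylphenyl into 2-fluorophenyl. Among the compounds with values here, no measured pair shows this swap, so the data give no direct guide to its size. In this assay the expectation is therefore a small move toward a lower number, with nothing beyond the scatter. The estimated step of a 1.3-fold lower number from compound 1 to compound 3 (0.12 log units; within the scatter) is modest and may prove to be no real change. Compound 3 is expected near 6.5 ug/mL in an estimated range from 2.5 ug/mL to 16 ug/mL on this read-out.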

Compound 3, half-maximal inhibitory concentration: 9.12 ug/mL
Compound 3: middle estimate off by 1.4-fold (0.15 log units), on the low side, within the range that was stated.
By their numbers in this assay, from the lowest: compound 2; then compounds 1 and 3 (each within the scatter of the next).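

In this assay, the swap of methyl for fluoro on this aromatic carbon comes out as a 1.1-fold higher number from compound 1 to compound 3 (0.03 log units; within the scatter), so on this read-out the two compounds cannot be told apart. Going by these compounds alone, this is the first single-place change, and it shows that, at this spot ortho to a large group, 2-methylphenyl and 2-fluorophenyl give readings that match within the usual scatter. Nothing available explains why these two groups read alike.

The compounds shown speak only for methyl and fluoro, so how an amine, a carboxylic acid or a longer chain such as propyl would read on this carbon stays open. Also open, as far as these compounds go, is whether the same swap would read alike on another carbon of this ring.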